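Changing the Amide Substituent on a Cytotoxicity-Silent Core

A few compounds are considered here, and "the series" means these few. Any claim that something is new, unique, unknown or untested is made for them only; others in the source may bear on it.

In a functional assay on A549 cells (Homo sapiens) for cytotoxicity, read by MTT assay, with a stated time of 24 h (a lower number here means a stronger inhibitor, a higher number a weaker inhibitor), compound 2 `C=CC1=C(C(=O)NCc2ccc(Cl)cc2)C(c2ccc(OC)cc2)OC1` returns only a limit, > 100000 nM. Compound 1 `C=CC1=C(C(=O)NCc2ccc(Cl)cc2)C(c2ccc(OC)c(OC)c2)OC1` likewise gives only a limit in this assay, > 100000 nM. Compound 3 `C=CC1=C(C(=O)NCCC)C(c2ccc(F)cc2)OC1` also gives only a limit, > 100000 nM. Among the compounds with values here, the single one-point comparison among them, a step that the two limits leave unreadable from compound 1 to compound 2, therefore cannot be read, since both of its ends are limits. The picture of this series is summarised by the limit of > 100000 nM in this assay, at which 3 of the 3 values shown sit.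

Compound 4 `C=CC1=C(C(=O)Nc2ccc(OCC)cc2)C(c2ccc(OC)cc2)OC1` differs from compound 2 in one place: 4-ethoxyphenyl in place of 4-chlorobenzyl on an amide-type nitrogen. Within the data shown here, no measured step touches this position on the amide-type nitrogen, so nothing in the data speaks for or against a change in this assay from that replacement. Among the measured compounds shown here, because the limit of > 100000 nM in this assay, at which 3 of the 3 values shown sit, describes every compound measured so far, compound 4 is expected to remain at that limit as well. The step that the limit leaves unreadable from compound 2 to compound 4 is accordingly expected to be none beyond the scatter. Compound 4 is estimated at 150000 nM, with a range from 50000 nM to 500000 nM.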

Compound 4, half-maximal inhibitory concentration: 17600 nM
For compound 4 the middle estimate is 8.5-fold (0.93 log units) above the measured one, and the stated range ends above it.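

The amide-type nitrogen is the first position in this series shown to affect the read-out: in this assay, replacing 4-chlorobenzyl with 4-ethoxyphenyl gives an at least 5.6-fold lower number from compound 2 to compound 4 (0.75 log units; beyond the scatter). The core of compound 2 is therefore not silent in itself, and the group on this nitrogen can bring a measurable value. The entering group also carries a hydrogen-bond acceptor that the leaving group lacks, and compound 4 is the only compound shown that stands apart from the rest: the limit of > 100000 nM in this assay, at which 3 of the 4 values shown sit.

Within the data shown here, the single step cannot tell whether the ethoxy group, the loss of the chlorine or the change from benzyl to phenyl accounts for the shift, and its full size stays unknown since compound 2 gives only a limit. It also leaves open whether an unsubstituted phenyl or a 4-aminophenyl on this nitrogen would hold or extend the change.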